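Swapping a Methyl for a Nitrile on an Inactive Scaffold

The source may hold more compounds than are shown below. What is called first, only, known or untested is meant among the compounds shown, and "the series" means these compounds.

Compound 1 `Cc1cccc(Cn2cc(COc3ccc4c(=O)ccoc4c3)nn2)c1` has been tested in a functional assay on HeLa cells (Homo sapiens) for cytotoxicity, read by MTT assay, with a stated time of 48 h; on this read-out higher numbers stand for weaker inhibition and lower numbers for stronger inhibition. In this assay compound 1 gives > 100000 nM, which is a limit of the assay rather than a number. Compound 2 `O=c1ccoc2cc(OCc3cn(Cc4ccccc4F)nn3)ccc12` differs from compound 1 only by 2-fluorophenyl in place of 3-methylphenyl on a saturated chain carbon bound to an aromatic nitrogen. In this assay compound 2 gives > 100000 nM, again a limit of the assay. The step that the two limits leave unreadable from compound 1 to compound 2 therefore cannot be read in size. Both values shown so far sit at the same limit (the limit of > 100000 nM in this assay, at which 2 of the 2 values shown sit), so compound 1 stands at that limit with nothing ranked around it. Compound 3 `N#Cc1ccc(Cn2cc(COc3ccc4c(=O)ccoc4c3)nn2)cc1` is not yet measured; it differs from compound 1 as follows: 4-cyanophenyl in place of 3-methylphenyl on a saturated chain carbon bound to an aromatic nitrogen. Among the compounds with values here, no measured step bears on this change, since the only step recorded is unreadable. The step of a number no higher from compound 1 to compound 3 (the limit leaves the size open) is expected to show no readable movement away from the limit. Compound 3 is estimated at 100000 nM, with a range from 30000 nM to 300000 nM.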

Compound 3, half-maximal inhibitory concentration: > 100000 nM
Compound 3 ended at the assay's limit; the forecaster's own chance of this, stated with the estimate: 80%; the middle value sits exactly at the limit.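

Compound 1, compound 2 and compound 3 all stop at one limit in this assay, so no step among them can be read in size: the limit of > 100000 nM in this assay, at which 3 of the 3 values shown sit.

The compounds shown leave open whether 3-methylphenyl, 2-fluorophenyl and 4-cyanophenyl differ at all in their effect on these cells, and what change would bring a real number within reach.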